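This account rests on a few compounds, and the source may have more. Where it says the series, first, only, none or still open, it means among the compounds named here.

Measured in a functional assay on DU-145 cells (Homo sapiens) for inhibition, read by trypan blue exclusion, with a stated time of 72 h; a higher number here means a weaker inhibitor, a lower number a stronger inhibitor:
- Compound 1 `Cn1c(=O)c(S(=O)(=O)c2ccc(F)cc2)cc2cnc(Nc3ccc4occc4c3)nc21`: 5000 nM
- Compound 2 `Cn1c(=O)c(S(=O)(=O)c2ccc(F)cc2)cc2cnc(Nc3ccc4[nH]ccc4c3)nc21`: 300 nM

Of these two, compound 2 has the lower number at 300 nM, which makes it the stronger inhibitor. The next step leads to compound 3 `Cn1c(=O)c(S(=O)(=O)c2ccc(F)cc2)cc2cnc(Nc3ccc4[nH]cnc4c3)nc21`, which has 1H-benzimidazol-5-yl in place of 1H-indol-5-yl on a nitrogen on an aromatic ring. The core and the rest of the molecule stay the same.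

Within the data shown here, only one measured step bears on this change: a 17-fold lower number from compound 1 to compound 2 (1.22 log units; beyond the scatter), a large step that came with 1H-indol-5-yl replacing 1-benzofuran-5-yl at the same place. It shows that exchanging this group can move the number considerably in this assay, so the new change cannot be assumed to be silent. However, that single step does not establish a direction for the benzimidazolyl group, and no measured compound carries it. A moderate rise is expected, smaller than the measured step, though a fall cannot be excluded. The expected step is a 2.3-fold higher number from compound 2 to compound 3 (0.37 log units; beyond the scatter). For compound 3 the estimate is 700 nM, with an expected range from 150 nM to 3000 nM.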

Compound 3, half-maximal inhibitory concentration: 10000 nM
The estimate for compound 3 lay 14-fold (1.15 log units) below the measured number; measured number outside the range, above it.
By their numbers in this assay, from the lowest: compound 2; then compounds 1 and 3 (each within the scatter of the next).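

In this assay, the exchange of 1H-indol-5-yl for 1H-benzimidazol-5-yl on a nitrogen on an aromatic ring gives a 33-fold higher number from compound 2 to compound 3 (1.52 log units; beyond the scatter), showing that this place is sensitive to a change of one ring atom, from carbon to nitrogen, while the core and the rest of the molecule stay the same. Now both groups compared with 1H-indol-5-yl are linked to large steps in the same direction, whereas 1H-benzimidazol-5-yl in place of 1-benzofuran-5-yl gives a 2.0-fold higher number from compound 1 to compound 3 (0.30 log units; within the scatter), so these two groups cannot be told apart in this assay, and among the three groups only 1H-indol-5-yl stands apart. Nothing available explains the size of this step or why 1H-indol-5-yl stands apart.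

The compounds shown leave open whether any other group at this place can match or improve on the number of compound 2, since they offer no reading for 1H-indol-5-yl carrying an added methyl, amine or carboxylic acid. They also leave open whether the same sensitivity would hold with a different group in place of the 4-fluorophenyl sulfonyl part.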